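This account rests on a few compounds, and the source may have more. Where it says the series, first, only, none or still open, it means among the compounds named here.

In a functional assay on A-375 cells (Homo sapiens) for inhibition, with a stated time of 72 h (a higher number here means a weaker inhibitor, a lower number a stronger inhibitor), compound 1 `CNC(=O)C1=C[C@@H]2[C@@H](C(C)C)CC[C@@](O)(CO)[C@H]2C(=O)OC1` gives > 32000 nM, which is a limit of the assay and not a number. Compound 2 `CC(C)[C@H]1CC[C@@](O)(CO)[C@H]2C(=O)OCC(C(=O)O)=C[C@H]12` gives > 32000 nM, again a limit and not a number. The whole picture so far is therefore (the limit of > 32000 nM in this assay, at which 2 of the 2 values shown sit), and compound 2 has no exact place on the scale.

Compound 3 `CC(C)[C@H]1CC[C@@](O)(CI)[C@H]2C(=O)OCC(C(=O)O)=C[C@H]12` differs from compound 2 by one exchange, iodo in place of hydroxy on a saturated chain carbon bound to a saturated ring carbon, or hydroxymethyl to iodomethyl when cut one bond further out.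

Within the data shown here, the only measured step is a step that the two limits leave unreadable from compound 1 to compound 2. It swaps hydroxy for methylamino on a carbonyl carbon, which is a different change, and it offers no size to carry over. The expectation in this assay is therefore loose: a modest step at most, towards a stronger inhibitor, with another limit as the likeliest report. The expected change is an at least 1.2-fold lower number from compound 2 to compound 3 (0.10 log units; that floor lies within the scatter). For compound 3 the estimated value is 25000 nM, with an expected range of 8000 nM to 64000 nM.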

Compound 3, half-maximal inhibitory concentration: > 10000 nM
Compound 3: a limit, no number; the forecaster's own chance of this, stated with the estimate: 65%; the middle value lies beyond the limit too.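

Among these compounds, compound 2 and compound 3 are both reported only as limits in this assay, not as numbers, so no step between them can be read for the exchange of hydroxy for iodo. The compounds shown leave open whether any of them has a measurable inhibitory value, and whether this exchange changes inhibition at all.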